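Swapping Cyano for Hydroxy in a Weakly Active Series

The compounds below may be only part of what the source reports. "The series", "measured", "known", "first", "only" and "open" are said of these compounds alone.

Three relatives have been measured in a functional assay on DLD-1 cells (Homo sapiens) for antiproliferative activity, read by trypan blue exclusion; on this read-out higher numbers stand for weaker inhibition and lower numbers for stronger inhibition. Compound 1 `COc1cc(OC)c(/C=C/S(=O)(=O)Cc2cc(OC)c(OC)c(OC)c2)c(OC)c1` gives > 20000 nM, which is a limit of the assay and not a number. Compound 2 `COc1cc(OC)c(/C=C/S(=O)(=O)Cc2ccc([N+](=O)[O-])cc2)c(OC)c1` gives 15000 nM. Compound 3 `COc1cc(OC)c(/C=C/S(=O)(=O)Cc2ccc(C#N)cc2)c(OC)c1` gives 20000 nM, so these two true numbers lie within the scatter of each other and no order can be read from them.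

Compound 4 `COc1cc(OC)c(/C=C/S(=O)(=O)Cc2ccc(O)cc2)c(OC)c1` has not yet been measured. It carries hydroxy in place of cyano on an aromatic carbon, para to a large group (hydroxy in place of cyano on an aromatic carbon). Among the measured compounds shown here, the only measured step that bears on this change is the swap of nitro for cyano, a 1.3-fold higher number from compound 2 to compound 3 (0.12 log units; within the scatter), which stays within the scatter. That step offers limited guidance, as hydroxy is a new group in this set, so the expectation leans only modestly toward a lower number and stronger inhibition. The expected step is a 2.9-fold lower number from compound 3 to compound 4 (0.46 log units; beyond the scatter). For compound 4 the estimated value is 7000 nM, with an expected range of 800 nM to 20000 nM.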

Compound 4, half-maximal inhibitory concentration: 20000 nM
Beside the measured number, compound 4's estimate is 2.9-fold (0.46 log units) below it, within the range that was stated.
By their numbers in this assay, from the lowest: compounds 2, 3 and 4 (each within the scatter of the next).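

In this assay, hydroxy brings a hydrogen-bond donor to this aromatic carbon, para to a large group, where cyano has none, yet the result is no change at the digits printed from compound 3 to compound 4 (within the scatter). Set against nitro, the same place gives a 1.3-fold higher number from compound 2 to compound 4 (0.12 log units; within the scatter). So a third, quite different group leaves compound 2, compound 3 and compound 4 without any readable order, and the numbers all lie at the weak end of what this assay can report: the limit of > 20000 nM in this assay, at which 1 of the 4 values shown sits.

Going by these compounds, whether any group on this carbon can bring the number down beyond the scatter remains open, and an amine or a carboxylic acid there would be a further test. Also open, on these data alone, is whether changes elsewhere on the shared core matter more than this position does.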